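A Glycoside Aglycone Swap Near the Assay Ceiling

This account rests on a few compounds, and the source may have more. Where it says the series, first, only, none or still open, it means among the compounds named here.

Measured compounds:
compound 1 `CC1=CC[C@@H](C(C)(C)O[C@@H]2O[C@H](COC(=O)c3cc(O)c(O)c(O)c3)[C@@H](O)[C@H](O)[C@H]2O)CC1` — 95.4%
compound 2 `COc1cc(CC(CO)O[C@@H]2O[C@H](COC(=O)c3cc(O)c(O)c(O)c3)[C@@H](O)[C@H](O)[C@H]2O)ccc1O` — 95.3%

In a functional assay, read by spectrophotometry, with a stated time of 30 min, tested at 40 uM (a lower number here means a weaker effect, a higher number a stronger effect of the compound at the concentration tested), compound 1 gives 95.4% and compound 2 gives 95.3%. The two numbers lie within the scatter of each other, so compound 1 cannot be set apart from compound 2; both sit close to the top of the percentage scale.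

Compound 3 `C=CCc1ccc(O[C@@H]2O[C@H](COC(=O)c3cc(O)c(O)c(O)c3)[C@@H](O)[C@H](O)[C@H]2O)c(OC)c1` keeps the shared core of compound 1 and changes the aglycone: 4-allyl-2-methoxyphenyl in place of 1-methyl-1-(4-methylcyclohex-3-en-1-yl)ethyl on an oxygen on a saturated carbon. The entering 4-allyl-2-methoxyphenyl group sits on an oxygen on a saturated carbon, where the 1-methyl-1-(4-methylcyclohex-3-en-1-yl)ethyl group of compound 1 stood.

For the measured compounds named here, no step between measured compounds is available to calibrate this change. Since both known numbers are near the ceiling, the step of a number 5.4 percentage points lower from compound 1 to compound 3 (within the scatter) is expected to be small, if anything a slight downward drift, and not beyond the scatter. Compound 3 is therefore estimated to give 90% in this assay, with a range from 75% to 99%.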

Compound 3, a percentage reported as activity, at one concentration (the size of the read-out at that concentration, not a potency): 95.2%
Compound 3: middle estimate off by 5.2 percentage points, on the low side, and the stated range covers the measured number.
By their numbers in this assay, from the lowest: compounds 3, 2 and 1 (each within the scatter of the next).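

In this assay, for the compounds shown here, putting the 4-allyl-2-methoxyphenyl group in place of the 1-methyl-1-(4-methylcyclohex-3-en-1-yl)ethyl group on an oxygen on a saturated carbon gives a number 0.2 percentage points lower from compound 1 to compound 3 (within the scatter), the only step available at this position. A six-membered non-aromatic ring of carbon only, carrying a defined stereocentre, thus gives way to a six-membered aromatic ring with one hydrogen-bond acceptor, and the read-out does not separate compound 1 from compound 3. No supporting measurement accounts for this result.

Both compounds lie close to the top of the percentage scale at a single concentration, so this read-out cannot show whether they would differ in potency. Going by these compounds, it also remains open whether an aglycone carrying an amine or a carboxylic acid would stay this close to the top of the scale.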